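From compound 3 to compound 4: methoxy in place of bromo

This account rests on a few compounds, and the source may have more. Where it says the series, first, only, none or still open, it means among the compounds named here.

Of the compounds shown here, three that share one core have been measured in a functional assay on HL-60 cells (Homo sapiens) for antiproliferative activity, read by sulforhodamine B assay, with a stated time of 72 h; a higher number here means a weaker inhibitor, a lower number a stronger inhibitor. Compound 1 `S=C(N/N=C/c1ccc2ccccc2n1)Nc1cccc(Cl)c1` gives 28800 nM. Compound 2 `S=C(N/N=C/c1ccc2ccccc2n1)Nc1cccc(Br)c1` gives 53800 nM, and the step of a 1.9-fold higher number from compound 1 to compound 2 (0.27 log units; within the scatter) is small. For compound 3 `S=C(N/N=C/c1ccc2ccccc2n1)Nc1ccccc1Br` the assay reports only a limit, > 100000 nM. Compound 3 therefore stands at the weak end of the set: an at least 3.4-fold higher number from compound 1 to compound 3 (0.54 log units; beyond the scatter), whereas an at least 1.8-fold higher number from compound 2 to compound 3 (0.26 log units; that floor lies within the scatter). The step followed here leads to compound 4 `COc1ccccc1NC(=S)N/N=C/c1ccc2ccccc2n1`, which differs from compound 3 in one place: methoxy in place of bromo on an aromatic carbon. Going by the values given here, none of the measured steps exchanges a bromo for a methoxy, so they bear on this step only by fixing where compound 3 starts, which is at the limit (the limit of > 100000 nM in this assay, at which 1 of the 3 values shown sits). Since compound 3 has no number, only a floor, compound 4 is expected to remain weak, with the step of a number no higher from compound 3 to compound 4 (the limit leaves the size open) judged not to move it beyond the scatter. Compound 4 is thus estimated at 100000 nM, within a range from 30000 nM to 300000 nM.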

Compound 4, half-maximal inhibitory concentration: 91700 nM
Compound 4: middle estimate off by 1.1-fold (0.04 log units), on the high side, and the stated range covers the measured number.
By their numbers in this assay, from the lowest: compounds 1, 2 and 4 (each within the scatter of the next, the first and the last beyond it). At a limit, above all of these: compound 3.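

With methoxy in place of bromo, this position now gives a true number rather than a limit in this assay, and the step, as far as it can be read, is an at least 1.0-fold lower number from compound 3 to compound 4 (0.03 log units; that floor lies within the scatter). Compound 3 still rests on a limit, so that step is only a floor: the limit of > 100000 nM in this assay, at which 1 of the 4 values shown sits. Measured against the 3-bromophenyl group, 2-methoxyphenyl gives a 1.7-fold higher number from compound 2 to compound 4 (0.23 log units; within the scatter), while against the 3-chlorophenyl group it gives a 3.2-fold higher number from compound 1 to compound 4 (0.50 log units; beyond the scatter), so only the second comparison shows a real difference.

Going by these compounds, how an amine, a carboxylic acid or a longer chain such as ethoxy would read at this position in this assay stays open. Also open, on these data alone, is how a 3-methoxyphenyl group would compare with 2-methoxyphenyl, which would test the place of the methoxy on the ring.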